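This account rests on a few compounds, and the source may have more. Where it says the series, first, only, none or still open, it means among the compounds named here.

Measured so far:

Compound 1, `CCCCCCCCCCCCNC(=O)[C@H]1OC(n2cnc3c(N)ncnc32)[C@H](O)[C@@H]1O`, in an assay on cell membranes for binding affinity to 2-oxoglutarate receptor 1 (Rattus norvegicus), read by radioligand binding (a lower number here means a stronger inhibitor, a higher number a weaker inhibitor), gives 163 nM.
Compound 2, `Nc1ncnc2c1ncn2[C@@H]1O[C@H](C(=O)NC2CCCC2)[C@@H](O)[C@H]1O`, in this assay gives 49 nM.
Compound 3, `Nc1ncnc2c1ncn2C1O[C@H](C(=O)NC2CCCCCC2)[C@@H](O)[C@H]1O`, in this assay gives 22 nM.

All three share the same nucleoside-like core and differ only in the group carried on the amide-type nitrogen. Compound 2, with its cyclopentyl group, stands second highest of the three numbers. Its nearest neighbour is compound 3, whose number is lower by a margin beyond the usual scatter, and the furthest is compound 1, whose number is higher, also beyond the scatter. Among these three, the two ring-bearing compounds sit below the long-chain compound 1.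

Compound 4, `C[C@H]1CC[C@@H](NC(=O)[C@H]2O[C@@H](n3cnc4c(N)ncnc43)[C@H](O)[C@@H]2O)CC1`, is not yet measured. It differs from compound 2 in one place: 4-methylcyclohexyl in place of cyclopentyl on an amide-type nitrogen. The change keeps the amide and the core untouched and only enlarges the ring on the nitrogen, moving from a five-membered to a six-membered carbon ring with one methyl attached.

Among the compounds with values here, no directly comparable step between two measured compounds exists here, so the expectation rests on the spread of the three numbers alone. Compound 3 carries a larger ring than compound 2 and gives the lowest number of the three, so a modest move downward for compound 4 in this assay is expected, roughly a 1.6-fold lower number from compound 2 to compound 4 (0.21 log units; within the scatter), though a result within the scatter of compound 2 would not surprise. Compound 4 is therefore estimated at 30 nM, with a plausible range from 12 nM to 80 nM.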

Compound 4, inhibition constant: 55.6 nM
Compound 4: the middle estimate sits 1.9-fold (0.27 log units) below what was measured, and the stated range covers the measured number.
By their numbers in this assay, from the lowest: compound 3; then compounds 2 and 4 (each within the scatter of the next); then compound 1.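

In this assay, replacing cyclopentyl with 4-methylcyclohexyl on the amide-type nitrogen gives a 1.1-fold higher number from compound 2 to compound 4 (0.05 log units; within the scatter). Within the data shown here, this is the first direct comparison at this position, and it shows that a larger carbon ring carrying a methyl group can take the place of cyclopentyl with no change that can be told apart from ordinary measurement scatter. No measured information is available to explain why these two groups read alike.

This single step changes the ring size and adds the methyl group at the same time, so a plain cyclohexyl group on the same nitrogen would be needed to separate the two changes, and they may or may not be offsetting each other. The compounds shown also leave open whether the other stereoisomer of 4-methylcyclohexyl would read the same, and whether putting a hydroxyl group or an amine on the ring in place of the methyl would keep the number within the scatter of compound 4.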